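The source may report more compounds than this note shows. Statements on the series, on what has been measured and on what is new or still open speak of the compounds shown alone.

Among the compounds with values here, compound 2 `O=C1O[C@@H](CSc2cccs2)CN1c1ccc(-n2cc(-c3ccccn3)cn2)c(F)c1` sits at the top of the two numbers in hand for a physicochemical assay for lipophilicity, read by HPLC, measured as octanol-water partition; a higher number here means a more lipophilic compound, a lower number a more polar compound: compound 2 gives 4.29, while compound 1 `CCN1CCN(C[C@H]2CN(c3ccc(-n4cc(-c5ccccn5)cn4)c(F)c3)C(=O)O2)CC1` gives 2.19, and the one measured step, a number 2.10 log units higher from compound 1 to compound 2 (beyond the scatter), shows how far apart these two stand. Compound 3 `O=CNC[C@H]1CN(c2ccc(-n3cc(-c4ccccn4)cn3)c(F)c2)C(=O)O1` has not yet been measured in this assay. The change from compound 2 to compound 3 is formylamino in place of (thiophen-2-yl)sulfanyl on a saturated chain carbon bound to a saturated ring carbon. Within the data shown here, the only step that bears on it is the one already seen, in which a (thiophen-2-yl)sulfanyl group entered at the very same place and the reading rose by a large margin; here that group leaves again, and a formylamino group with its one hydrogen-bond donor takes its place, so a large step downward is expected. Since the step from compound 1 to compound 2 was a number 2.10 log units higher from compound 1 to compound 2 (beyond the scatter), the return is expected to be of similar size, and the step for compound 3 is estimated as a number 2.79 log units lower from compound 2 to compound 3 (beyond the scatter). Compound 3 is therefore expected to give about 1.5 in this assay, within a range of 0.8 to 2.2.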

Compound 3, partition coefficient: 1.19
Compound 3: middle estimate off by 0.31 log units, on the high side; the measured number falls inside the stated range.
By their numbers in this assay, from the lowest: compound 3; then compound 1; then compound 2.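

With compound 3, three groups have now been compared in this assay on a saturated chain carbon bound to a saturated ring carbon, and the shared core stays the same throughout. Exchanging (thiophen-2-yl)sulfanyl for formylamino gives a number 3.10 log units lower from compound 2 to compound 3 (beyond the scatter) and so spans the full range of the three readings, a wider gap than the one seen between the first two compounds. The reading also does not simply fall back to the level of compound 1, since replacing 4-ethylpiperazin-1-yl with formylamino gives a number 1.00 log units lower from compound 1 to compound 3 (beyond the scatter) and places compound 1 between the other two, with all three separated beyond the scatter. Nothing available here accounts for this order of the three groups.

The compounds shown leave open whether the reading of compound 3 is particular to formylamino or would be shared by an acetylamino group or a plain primary amine at the same place. They also leave open where phenylsulfanyl would fall relative to (thiophen-2-yl)sulfanyl, and whether a simple piperazin-1-yl would stay close to its 4-ethyl counterpart.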